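The source may report more compounds than this note shows. Statements on the series, on what has been measured and on what is new or still open speak of the compounds shown alone.

Compound 1 `O=C1C(=O)N(CCCCn2cc(COc3cc(=O)oc4ccccc34)nn2)c2ccc(Cl)cc21` carries a chloro group on the fused aromatic part of the shared core and a four-carbon chain to the triazole. In a functional assay on PC-3 cells (Homo sapiens) for inhibition, read by sulforhodamine B assay, with a stated time of 48 h, tested at 50 uM (on this read-out lower numbers stand for less inhibition of growth and higher numbers for more inhibition of growth at the one concentration tested), compound 1 gives 14%, the second highest of the three numbers. Compound 3 `O=C1C(=O)N(CCCn2cc(COc3cc(=O)oc4ccccc34)nn2)c2ccc([N+](=O)[O-])cc21`, with a three-carbon chain and a nitro group, gives 12% in this assay, within the scatter of compound 1. Compound 2 `O=C1C(=O)N(CCCn2cc(COc3cc(=O)oc4ccccc34)nn2)c2ccccc21`, with the three-carbon chain and no substituent on that ring, gives 25% in this assay, beyond the scatter above compound 1.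

Compound 4 `O=C1C(=O)N(CCCCn2cc(COc3cc(=O)oc4ccccc34)nn2)c2ccccc21` differs from compound 1 by one change: hydrogen in place of chloro on an aromatic carbon. Going by the values given here, the only measured step that bears on this change is the one in which a substituent enters the same ring, a number 13 percentage points lower from compound 2 to compound 3 (beyond the scatter). That step suggests removing a substituent could raise the number, though compound 1 and compound 2 differ in two places and so give no direct comparison. Compound 4 is therefore expected to show a modest rise, a number 8 percentage points higher from compound 1 to compound 4 (within the scatter), with an estimate of 22%, between 10% and 34%.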

Compound 4, percent growth inhibition at one concentration: 19%
For compound 4 the middle estimate is 3 percentage points above the measured one; the range from low to high includes it.
By their numbers in this assay, from the lowest: compounds 3, 1, 4 and 2 (each within the scatter of the next, the first and the last beyond it).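

Going by these compounds alone, with the rest of compound 1 unchanged, hydrogen in place of chloro on this aromatic carbon gives a number 5 percentage points higher from compound 1 to compound 4 (within the scatter) in this assay, the first direct reading of this change. At this level of growth inhibition, the chloro group and hydrogen cannot be told apart here, whereas the nitro step on a compound with a different chain, a number 13 percentage points lower from compound 2 to compound 3 (beyond the scatter), lies beyond the scatter. Nothing given here offers an explanation for this result.

On these data alone, whether an amine, a methoxy group or a carboxylic acid on this aromatic carbon would give a number beyond the scatter of compound 4 remains open. So does whether a nitro group would give a step of similar size on the compound with the chain of compound 4, or whether a longer chain would alter these numbers.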